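Chloroacetamide versus benzamide on a benzothiazole series

The compounds below may be only part of what the source reports. "The series", "measured", "known", "first", "only" and "open" are said of these compounds alone.

Compound 1 `O=C(CSc1nc2ccc(NC(=O)CCl)cc2s1)NCc1ccccc1` and compound 2 `O=C(CSc1nc2ccc(NC(=O)c3ccccc3)cc2s1)NCc1ccccc1` share a core and differ only at the carbonyl; in a functional assay on HepG2 cells (Homo sapiens) for cytotoxicity, read by MTT assay, with a stated time of 48 h (a higher number here means a weaker inhibitor, a lower number a stronger inhibitor), compound 1 gives 1100 nM and compound 2 gives 34200 nM, a step of a 31-fold lower number from compound 2 to compound 1 (1.49 log units; beyond the scatter), the change being (chloromethyl in place of phenyl on a carbonyl carbon). Compound 3 `COc1ccc(CNC(=O)CSc2nc3ccc(NC(=O)c4ccccc4)cc3s2)cc1` gives 12700 nM in this assay, a step of a 2.7-fold lower number from compound 2 to compound 3 (0.43 log units; beyond the scatter) from compound 2; the change there is methoxy in place of hydrogen on an aromatic carbon, and this is also how the core of compound 3 differs from that of compound 2. Compound 4 `COc1ccc(CNC(=O)CSc2nc3ccc(NC(=O)CCl)cc3s2)cc1` is not yet measured; it differs from compound 3 by chloromethyl in place of phenyl on a carbonyl carbon, the same change as between compound 2 and compound 1, made at the same place. A step of a 25-fold lower number from compound 3 to compound 4 (1.40 log units; beyond the scatter) is expected in this assay, resting on the size of a 31-fold lower number from compound 2 to compound 1 (1.49 log units; beyond the scatter). Compound 4 is therefore estimated at 500 nM, between 150 nM and 1800 nM.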

Compound 4, half-maximal inhibitory concentration: 2000 nM
The estimate for compound 4 lay 4.0-fold (0.60 log units) below the measured number; measured number outside the range, above it.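

In this assay, chloromethyl in place of phenyl on a carbonyl carbon lowers the number on both cores, here by a 6.4-fold lower number from compound 3 to compound 4 (0.80 log units; beyond the scatter), so the direction carries over but the size does not: the same change on two cores in this assay, a 31-fold lower number (1.49 log units; beyond the scatter) from compound 2 to compound 1 and a 6.4-fold lower number (0.80 log units; beyond the scatter) from compound 3 to compound 4, 4.9-fold (0.69 log units) apart, beyond the scatter of two such steps. Methoxy in place of hydrogen lowers the number with the benzamido group present, but with the ((chloromethyl)carbonyl)amino group present it gives a 1.8-fold higher number from compound 1 to compound 4 (0.26 log units; within the scatter), so the two changes do not simply add: the same change on two cores in this assay, a 2.7-fold lower number (0.43 log units; beyond the scatter) from compound 2 to compound 3 and a 1.8-fold higher number (0.26 log units; within the scatter) from compound 1 to compound 4, 4.9-fold (0.69 log units) apart, beyond the scatter of two such steps. These four compounds show this one mismatch but give neither its cause nor a rule for any further core.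

Open, on these data alone, is whether a plain methyl or a bromomethyl on that carbonyl carbon would track chloromethyl. Also open, as far as these compounds go, is whether a fluorine or a nitrile in place of methoxy would behave like methoxy on either core.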